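Extending the Side Chain from Compound 2 to Compound 3

The source may report more compounds than this note shows. Statements on the series, on what has been measured and on what is new or still open speak of the compounds shown alone.

Compound 1 `COCCOc1cc2ncnc(-n3nc(-c4ccccn4)nc3N)c2cc1OCCOC` gives 22.9 mL/min/kg in an ADME assay on liver (Mus musculus, strain CD-1) for metabolic stability, read by HPLC, using microsomes, with a stated time of 4 h (on this read-out higher numbers stand for fast clearance and lower numbers for slow clearance), and compound 2 `COCCOc1cc2c(-n3nc(-c4ccccn4)nc3N)ncnc2cc1OC` gives 27.1 mL/min/kg in the same test, so compound 2 stands level with compound 1 within the scatter. Compound 3 `COc1cc2ncnc(-n3nc(-c4ccccn4)nc3N)c2cc1OCCCNC(=O)OC(C)C` differs from compound 2 as follows: ((isopropoxycarbonyl)amino)methyl in place of methoxy on a saturated chain carbon, two bonds along the chain from an oxygen on an aromatic ring. In words, ((isopropoxycarbonyl)amino)methyl stands in place of methoxy on a saturated chain carbon, two bonds along the chain from an oxygen on an aromatic ring. For the measured compounds named here, one measured step bears on this change: a 1.2-fold higher number from compound 1 to compound 2 (0.07 log units; within the scatter), with hydrogen in place of methoxymethyl. Going by the values given here, no measured compound carries the entering group, so this step offers only weak guidance, and no shift beyond the scatter is expected in this assay. The expected step is a 1.1-fold higher number from compound 2 to compound 3 (0.04 log units; within the scatter), a tentative estimate. For compound 3 the estimated clearance is 30 mL/min/kg, with an expected range of 14 mL/min/kg to 65 mL/min/kg in this estimate.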

Compound 3, clearance: 329 mL/min/kg
Compound 3: the middle estimate sits 11-fold (1.04 log units) below what was measured; measured number above the stated range.
By their numbers in this assay, from the lowest: compounds 1 and 2 (each within the scatter of the next); then compound 3.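

Swapping the 2-methoxyethoxy chain for 3-((isopropoxycarbonyl)amino)propoxy brings a 12-fold higher number from compound 2 to compound 3 (1.08 log units; beyond the scatter) in this assay. The earlier step on this side chain, a 1.2-fold higher number from compound 1 to compound 2 (0.07 log units; within the scatter), had shown no shift beyond the scatter, so this result is the first sign among the compounds shown that the read-out responds to what is placed on a saturated chain carbon, two bonds along the chain from an oxygen on an aromatic ring. Nothing in hand explains the size of this rise.

The longer chain and the isopropoxycarbonyl group enter in a single step, so the compounds shown cannot assign the rise to either one. Also open, going by these compounds, is how the same propoxy chain would read if it ended in a methoxy, a free amine or a carboxylic acid.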